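Bromo in place of methyl: expectation for compound 4

The source may hold more compounds than are shown below. What is called first, only, known or untested is meant among the compounds shown, and "the series" means these compounds.

In a functional assay on WM-115 cells (Homo sapiens) for cytotoxicity, read by MTT assay, with a stated time of 46 h (on this read-out higher numbers stand for weaker inhibition and lower numbers for stronger inhibition), compound 2 (`Cc1ccc(/C=C2/C(=O)c3ccccc3OC2c2ccccc2)cc1`) gives 60100 nM and sits level with compound 1 (`Cc1ccc(/C=C2\C(=O)c3ccccc3OC2c2ccccc2)cc1`) at 57000 nM while compound 3 (`O=C1/C(=C\c2ccc(Cl)cc2)C(c2ccccc2)Oc2ccccc21`) reads lower at 27400 nM on the same scale.

Compound 4 (`O=C1/C(=C/c2ccc(Br)cc2)C(c2ccccc2)Oc2ccccc21`) has not yet been measured. It differs from compound 2 by bromo in place of methyl on an aromatic carbon, para to a large group (bromo in place of methyl on an aromatic carbon), so 4-methylphenyl becomes 4-bromophenyl.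

Among the compounds with values here, two measured steps bear on this change. The change in how the double bond is drawn gave a 1.1-fold higher number from compound 1 to compound 2 (0.02 log units; within the scatter) and so offers no reason to keep the two double bond forms apart in this small set. Chloro in place of methyl on an aromatic carbon in compound 3 gave a 2.1-fold lower number from compound 1 to compound 3 (0.32 log units; beyond the scatter) as the only swap of this kind. Carried over to bromo, that modest step leads to the expectation of a lower number of similar size in this assay with only a single precedent behind it.

The estimated step is a 2.2-fold lower number from compound 2 to compound 4 (0.35 log units; beyond the scatter) in this series. For compound 4 the estimate is 27000 nM with an expected range from 13000 nM to 55000 nM in this measurement.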

Compound 4, half-maximal inhibitory concentration: 25900 nM
For compound 4 the middle estimate is 1.0-fold (0.02 log units) above the measured one, and the stated range covers the measured number.
By their numbers in this assay, from the lowest: compounds 4 and 3 (each within the scatter of the next); then compounds 1 and 2 (each within the scatter of the next).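

In this assay, going from 4-methylphenyl to 4-bromophenyl gives a 2.3-fold lower number from compound 2 to compound 4 (0.37 log units; beyond the scatter), which runs in the same direction as the chloro swap in a 2.1-fold lower number from compound 1 to compound 3 (0.32 log units; beyond the scatter). A lower number on replacing methyl with a halogen at this place on the aromatic ring therefore no longer rests on a single pair, and it now appears with both drawn forms of the double bond. Any reading of these two steps as one effect, independent of the double bond, remains limited by a feature of the drawings: the fact that one of compounds 1 and 2 is drawn with a defined configuration and the other without, at the place where they differ

The compounds shown cover only methyl, chloro and bromo at this place, so it remains open whether the lower number belongs to halogens as a class or would also follow from other replacements of methyl, such as a methoxy group, an amine or a carboxylic acid. Also open, from the compounds shown here alone, is whether fluoro or iodo would continue the same trend, and how the series responds to changes elsewhere on the shared core.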